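Bromo for Iodo at a Second Place on the Core

This account rests on a few compounds, and the source may have more. Where it says the series, first, only, none or still open, it means among the compounds named here.

The measured compounds, each with its number in an assay on isolated protein for inhibition of Calpain-1 catalytic subunit (Sus scrofa), read by FRET; a higher number here means a weaker inhibitor, a lower number a stronger inhibitor:
compound 1, `O=C(O)/C(S)=C/c1c[nH]c2cc(Br)ccc12`: 7 nM
compound 2, `O=C(O)/C(S)=C/c1c[nH]c2cc(I)ccc12`: 170 nM
compound 3, `O=C(O)/C(S)=C/c1c[nH]c2c(I)cccc12`: 90 nM

Compound 2 and compound 1 differ in one place, (bromo in place of iodo on an aromatic carbon). In this assay that exchange gave a 24-fold lower number from compound 2 to compound 1 (1.39 log units; beyond the scatter). Compound 3 has the same atoms as compound 2, joined differently; the difference between the two cores is not broken down here. In this assay compound 3 and compound 2 lie within the scatter of each other, while compound 1 sits well apart from both.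

Compound 4, `O=C(O)/C(S)=C/c1c[nH]c2c(Br)cccc12`, has not yet been measured. It differs from compound 3 by bromo in place of iodo on an aromatic carbon. This is the same kind of change as from compound 2 to compound 1, but the place is ortho to a fused ring and meta to a fused ring, whereas the earlier one was meta to a fused ring and para to a fused ring.

Compound 4 is expected to give about 15 nM in this assay, most likely between 4 nM and 60 nM, because the same kind of change gave a 24-fold lower number from compound 2 to compound 1 (1.39 log units; beyond the scatter). That estimate means a step of a 6.0-fold lower number from compound 3 to compound 4 (0.78 log units; beyond the scatter), kept somewhat smaller than the earlier one since the place is not the same.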

Compound 4, half-maximal inhibitory concentration: 2 nM
Estimate against measurement, compound 4: 7.5-fold (0.88 log units) above, and the stated range ends above it.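

In this assay, bromo in place of iodo on an aromatic carbon gave a 45-fold lower number from compound 3 to compound 4 (1.65 log units; beyond the scatter), and this step does not differ from the one seen earlier on the other core: the same change on two cores in this assay, a 24-fold lower number (1.39 log units; beyond the scatter) from compound 2 to compound 1 and a 45-fold lower number (1.65 log units; beyond the scatter) from compound 3 to compound 4, 1.9-fold (0.27 log units) apart, within the scatter of two such steps

The exchange therefore carried from one core to the other, in the same direction and at a size that cannot be told apart, even though the place on the ring is not the same in the two pairs. This rests on two pairs in a single assay, so it does not explain why bromo gives the lower number, and it does not show that the step would hold at any other place on the ring or on any other core.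

What the compounds shown leave open is how a smaller halogen such as chloro or fluoro would compare with bromo at these same two places. On these data alone, it also remains open whether a group of another kind, such as methyl or a nitrile, would give a comparable number there.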